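Benzofuran for piperidinylcarbonyl on the aryl amine series

A few compounds are considered here, and "the series" means these few. Any claim that something is new, unique, unknown or untested is made for them only; others in the source may bear on it.

The series shares the core of compound 1 `COC(=O)c1ccc(NCc2cncn2Cc2ccccc2Cl)cc1-c1ccccc1`, which in a toxicity assay on NIH3T3 cells (Mus musculus) for cytotoxicity, read by resazurin assay (on this read-out lower numbers stand for an effect already at smaller amounts and higher numbers for an effect only at larger amounts of compound), gives 10000 nM. Compound 3 `COC(=O)c1ccc(NCc2cncn2Cc2ccc(F)cc2F)cc1-c1ccccc1` stops at a limit of the assay, > 1000 nM. Hence a step that the limit leaves unreadable from compound 1 to compound 3. Compound 2 `O=C(c1ccc(NCc2cncn2Cc2ccc(-c3ccccc3)cc2)cc1-c1ccccc1)N1CCCCC1` likewise reaches only a limit in this assay, > 1000 nM, so its standing cannot be placed against compound 1 beyond that; (the limit of > 1000 nM in this assay, at which 2 of the 3 values shown sit). Compound 4 `c1ccc(-c2ccc(Cn3cncc3CNc3ccc(-c4cc5ccccc5o4)c(-c4ccccc4)c3)cc2)cc1` differs from compound 2 by 1-benzofuran-2-yl in place of (piperidin-1-yl)carbonyl on an aromatic carbon. Within the data shown here, no measured step touches this position, so no size or direction is expected beyond the scatter, and compound 4 is estimated at 5000 nM, within 1500 nM to 20000 nM, most likely again reported only as a limit; the expected step that the limit leaves unreadable from compound 2 to compound 4 is therefore nominal.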

Compound 4, half-maximal effective concentration: > 10000 nM
Compound 4 gave a limit, no number; the forecaster's own chance of this, stated with the estimate: 60%; at least 2.0-fold (0.30 log units) between middle value and limit.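

In this assay compound 4 gives only a limit (> 10000 nM). Among these compounds, compound 2 likewise gives only a limit (> 1000 nM), so no step between compound 2 and compound 4 can be read. From the compounds shown here alone, whether 1-benzofuran-2-yl in place of (piperidin-1-yl)carbonyl changes the read-out at all stays open.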